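The compounds below may be only part of what the source reports. "The series", "measured", "known", "first", "only" and "open" are said of these compounds alone.

Measured compounds:
- compound 1, `O=C(/C=C/c1ccc2c(c1)B(O)OC2)c1ccccc1`: 2300 nM
- compound 2, `O=C(/C=C/c1ccc2c(c1)B(O)OC2)c1cccnc1`: 11400 nM

Both compounds share one core and differ only in the aromatic group attached to the carbonyl carbon. In a functional assay on MDA-MB-231 cells (Homo sapiens) for cytotoxicity, read by MTT assay, with a stated time of 48 h (on this read-out lower numbers stand for stronger inhibition and higher numbers for weaker inhibition), compound 1 gives 2300 nM, whereas compound 2 gives 11400 nM, the highest number of the two; the change a 5.0-fold higher number from compound 1 to compound 2 (0.70 log units; beyond the scatter) is modest but beyond the scatter.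

Compound 3, `Cn1cccc1C(=O)/C=C/c1ccc2c(c1)B(O)OC2`, has not yet been measured. It differs from compound 2 in one place: 1-methyl-1H-pyrrol-2-yl in place of pyridin-3-yl on a carbonyl carbon. Among the compounds with values here, the only step that bears on this change is the one from compound 1 to compound 2, which swapped one aromatic group for another on the same carbonyl carbon and gave a modest shift. Since that step shows the group on the carbonyl carbon can move the number by a modest amount, a modest step is expected here as well; its direction is uncertain, but a move back toward the number of compound 1 seems somewhat more likely than a further rise. For compound 3 the expected value in this assay is 5000 nM (range 1500 nM to 15000 nM), which corresponds to an estimated step of a 2.3-fold lower number from compound 2 to compound 3 (0.36 log units; beyond the scatter).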

Compound 3, half-maximal inhibitory concentration: > 100000 nM
Compound 3: only a limit was reported; the forecaster's own chance of this, stated with the estimate: 5%; at least 20-fold (1.30 log units) between middle value and limit.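

For compound 3 the reading in this assay is a limit and not a number: the limit of > 100000 nM in this assay, at which 1 of the 3 values shown sits. Even so, placing 1-methyl-1H-pyrrol-2-yl on the carbonyl carbon instead of pyridin-3-yl gives an at least 8.7-fold higher number from compound 2 to compound 3 (0.94 log units; beyond the scatter), and placing it there instead of phenyl gives an at least 43-fold higher number from compound 1 to compound 3 (1.63 log units; beyond the scatter). The group on this carbonyl carbon can therefore matter far more than the earlier change alone showed, which was a 5.0-fold higher number from compound 1 to compound 2 (0.70 log units; beyond the scatter), even though the entering and leaving groups in the newest change match in heavy atoms, hydrogen-bond donors and hydrogen-bond acceptors.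

The compounds shown cannot separate the five-membered aromatic ring of compound 3 from the methyl group on its nitrogen, so either feature, or the two together, could lie behind the loss. A plain 1H-pyrrol-2-yl group would test the methyl group, while a thiophen-2-yl or furan-2-yl group on the same carbonyl carbon would show whether other five-membered aromatic rings behave in the same way, and no cause for the result can be drawn from these three compounds.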